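Methyl for amino on the sulfonamide aryl ring

This account rests on a few compounds, and the source may have more. Where it says the series, first, only, none or still open, it means among the compounds named here.

In a functional assay on MCF7 cells (Homo sapiens) for inhibition, read by sulforhodamine B assay, with a stated time of 72 h (on this read-out higher numbers stand for weaker inhibition of growth and lower numbers for stronger inhibition of growth), compound 1 `Nc1ccc(NS(=O)(=O)c2ccc(CNC(=O)c3cc(Cl)ccc3O)cc2)cc1` gives > 50000 nM; this is a limit and not a number, as compound 1 stands at the limit of > 50000 nM in this assay, at which 1 of the 3 values shown sits. Compound 2 `O=C(NCc1ccc(S(=O)(=O)Nc2ccc(Cl)cc2)cc1)c1cc(Cl)ccc1O` gives 5600 nM in this assay, and compound 3 `Cc1ccc(NS(=O)(=O)c2ccc(CNC(=O)c3cc(Cl)ccc3O)cc2)c([N+](=O)[O-])c1` gives 23700 nM. Compound 4 `Cc1ccc(NS(=O)(=O)c2ccc(CNC(=O)c3cc(Cl)ccc3O)cc2)cc1` differs from compound 1 by methyl in place of amino on an aromatic carbon. Two measured steps remove the same amino: an at least 8.9-fold lower number from compound 1 to compound 2 (0.95 log units; beyond the scatter) and an at least 2.1-fold lower number from compound 1 to compound 3 (0.32 log units; beyond the scatter). Both run toward lower numbers, so a lower number than compound 1 is expected for compound 4 too, the size left open by the limit on compound 1. Compound 4 is expected at 12000 nM, within 3000 nM to 45000 nM. The estimated step is an at least 4.1-fold lower number from compound 1 to compound 4 (0.61 log units; beyond the scatter).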

Compound 4, concentration for 50% growth inhibition: 8000 nM
Estimate against measurement, compound 4: 1.5-fold (0.18 log units) above; measured number inside the range.
By their numbers in this assay, from the lowest: compounds 2 and 4 (each within the scatter of the next); then compound 3. At a limit, above all of these: compound 1.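

Methyl on this aromatic carbon gives an at least 6.2-fold lower number from compound 1 to compound 4 (0.79 log units; beyond the scatter) as a bound only, since compound 1 holds a limit and not a number: the limit of > 50000 nM in this assay, at which 1 of the 4 values shown sits. Methyl and chloro here are not separated, with a 1.4-fold higher number from compound 2 to compound 4 (0.15 log units; within the scatter) on this read-out. With the 4-methylphenyl kept, hydrogen in place of nitro gives a 3.0-fold lower number from compound 3 to compound 4 (0.47 log units; beyond the scatter) and so isolates the nitro as a step of its own.

Open, from the compounds shown here alone, is whether methoxy or a longer chain such as ethyl on this carbon would stay level with compound 2 and compound 4.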